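The compounds below may be only part of what the source reports. "The series", "measured", "known", "first", "only" and "open" are said of these compounds alone.

Measured in a functional assay on Vero cells (Chlorocebus sabaeus) for inhibition; a higher number here means a weaker inhibitor, a lower number a stronger inhibitor:
- compound 1 `Clc1ccc(Cn2cnc3c(-c4ccco4)ncnc32)cc1`: > 62.5 ug/mL
- compound 2 `COc1ccc(Cn2cnc3c(-c4ccco4)ncnc32)cc1`: > 62.5 ug/mL

Neither entry is a true number. Compound 1 gives > 62.5 ug/mL, which is a limit of the assay. Compound 2 gives > 62.5 ug/mL, which is also a limit, so its place on the scale is known only as a limit and not as a point. Both compounds share this one mark: the limit of > 62.5 ug/mL in this assay, at which 2 of the 2 values shown sit.

The next compound is compound 3 `CCOc1ccc(Cn2cnc3c(-c4ccco4)ncnc32)cc1`. It differs from compound 2 by methyl in place of hydrogen on a saturated chain carbon bound to an oxygen on an aromatic ring, which turns methoxy into ethoxy.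

Among the measured compounds shown here, only one measured step bears on this change, and it is a step that the two limits leave unreadable from compound 1 to compound 2. That step put methoxy in place of chloro on an aromatic carbon, and it gives no size that could be carried over. For the measured compounds named here, with that step as the only guide, no change beyond the usual scatter is expected in this assay, in either direction. Most likely the assay will again report only a limit.

Compound 3 is estimated at 65 ug/mL, with an expected range from 25 ug/mL to 130 ug/mL. This estimate means an expected step that the limit leaves unreadable from compound 2 to compound 3.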

Compound 3, half-maximal inhibitory concentration: 37.4 ug/mL
Compound 3: the middle estimate sits 1.7-fold (0.24 log units) above what was measured; low and high end bracket the measured number.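

Of the compounds shown, compound 3 alone gives a true number in this assay, so a change at this position can bring the compound within the measurable range: going from methoxy to ethoxy gives an at least 1.6-fold lower number from compound 2 to compound 3 (0.22 log units; that floor lies within the scatter). Ethoxy in place of chloro gives an at least 1.6-fold lower number from compound 1 to compound 3 (0.22 log units; that floor lies within the scatter), and as both steps are only floors, the real difference could be small or considerably larger. The step from compound 1 to compound 2 cannot be read, and those two compounds share one mark, which is a limit and not a number: the limit of > 62.5 ug/mL in this assay, at which 2 of the 3 values shown sit.

From the compounds shown here alone, a single added methyl makes no trend, so it remains open whether a propoxy group or a longer chain on the same oxygen would lower the number further. Also open, going by these compounds, is whether an amine or a carboxylic acid at the end of such a chain would still give a true number.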